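From 3,5-dimethylphenyl to 3-cyanophenyl in compound 3

This account rests on a few compounds, and the source may have more. Where it says the series, first, only, none or still open, it means among the compounds named here.

- compound 1 `O=C1CN(S(=O)(=O)c2c(Cl)cccc2Cl)c2cc(Cl)ccc2N1`: > 319000 nM
- compound 2 `Cc1cc(C)cc(S(=O)(=O)Nc2cc(Cl)ccc2NC(=O)CCl)c1`: 35100 nM

For the measured compounds named here, in an ADME assay on MT4 cells (Homo sapiens) for cytotoxicity, with a stated time of 5 days (a higher number here means that more compound is tolerated, a lower number that less compound is tolerated), compound 2 gives 35100 nM, the only exact number so far. For compound 1 the entry > 319000 nM is a limit of the assay and not a number.

Compound 3 `N#Cc1cccc(S(=O)(=O)Nc2cc(Cl)ccc2NC(=O)CCl)c1` has not yet been measured. It differs from compound 2 by having 3-cyanophenyl in place of 3,5-dimethylphenyl on a sulfonyl sulfur. Going by the values given here, no pair of measured compounds shows what a change at this place does, so the only anchor is compound 2 at 35100 nM. In this assay no step beyond the usual scatter is expected, and no clear direction can be predicted. The estimated change is a 1.1-fold higher number from compound 2 to compound 3 (0.06 log units; within the scatter). For compound 3 the expected value is 40000 nM, with an estimated range of 14000 nM to 120000 nM.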

Compound 3, half-maximal cytotoxic concentration: > 155000 nM
Compound 3: no number, only a limit; the forecaster's own chance of this, stated with the estimate: 15%; middle value at least 3.8-fold (0.58 log units) away from the limit.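

In this assay, replacing 3,5-dimethylphenyl with 3-cyanophenyl on a sulfonyl sulfur gives an at least 4.4-fold higher number from compound 2 to compound 3 (0.64 log units; beyond the scatter), the first measured sign that a change at this place can matter. The two groups have the same number of heavy atoms, yet this single swap moves the number beyond the usual scatter, so the cells tolerate more of compound 3 than of compound 2. The entry for compound 3 is a limit of the assay and not a number, so the full size of the step stays unknown: the limit of > 155000 nM in this assay, at which 1 of the 3 values shown sits.

The pair cannot separate the effect of adding the nitrile from that of removing the two methyl groups, and a plain phenyl ring or a 3-methylphenyl group would help to tell these apart. Compound 1 differs from both compounds in more than one place, so it says nothing about this change.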